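The compounds below may be only part of what the source reports. "The series", "measured", "known", "first", "only" and "open" are said of these compounds alone.

Measured in a toxicity assay on MT4 cells (Homo sapiens) for cytotoxicity, read by MTT assay, with a stated time of 5 days; on this read-out higher numbers stand for lower toxicity in this test and lower numbers for higher toxicity in this test:
- compound 1 `Cc1cc(-c2ccc3cc[nH]c3c2)cc(C)c1Nc1ccnc(Nc2ccc(C#N)cc2)n1`: 5800 nM
- compound 2 `Cc1ccc(-c2cc(C)c(Nc3ccnc(Nc4ccc(C#N)cc4)n3)c(C)c2)s1`: 28000 nM
- compound 3 `Cc1cc(-c2cc(C)c(Nc3ccnc(Nc4ccc(C#N)cc4)n3)c(C)c2)ccn1`: 4900 nM

Compound 3 sits level with compound 1 within the scatter, a 1.2-fold lower number from compound 1 to compound 3 (0.07 log units; within the scatter). Compound 2 stands apart from both, with a 5.7-fold lower number from compound 2 to compound 3 (0.76 log units; beyond the scatter) and a 4.8-fold higher number from compound 1 to compound 2 (0.68 log units; beyond the scatter), each a modest step beyond the scatter.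

Next is compound 4 `Cc1cc(-c2cc(C)c(Nc3ccnc(Nc4ccc(C#N)cc4)n3)c(C)c2)cc(C)n1`, which turns the 2-methylpyridin-4-yl of compound 3 into 2,6-dimethylpyridin-4-yl: methyl in place of hydrogen on an aromatic carbon. In words, this is methyl in place of hydrogen on an aromatic carbon.

For the measured compounds named here, no measured step makes this exact exchange, so the evidence is indirect. The three steps available all swap the whole group on the shared core. Even those swaps moved this assay only modestly at most, and the exchange between 1H-indol-6-yl and 2-methylpyridin-4-yl gave a 1.2-fold lower number from compound 1 to compound 3 (0.07 log units; within the scatter). A single added methyl is a much smaller change than any of these, so no shift beyond the scatter is expected, with at most a slight drift to a higher number.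

The expected step is a 1.2-fold higher number from compound 3 to compound 4 (0.09 log units; within the scatter). For compound 4 the estimated value is 6000 nM, with an expected range from 2500 nM to 15000 nM.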

Compound 4, half-maximal cytotoxic concentration: 2300 nM
The estimate for compound 4 lay 2.6-fold (0.42 log units) above the measured number; measured number below the stated range.
By their numbers in this assay, from the lowest: compound 4; then compounds 3 and 1 (each within the scatter of the next); then compound 2.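

In this assay, adding methyl in place of hydrogen on the aromatic carbon next to the ring nitrogen gives a 2.1-fold lower number from compound 3 to compound 4 (0.33 log units; beyond the scatter), so a change of 1 heavy atom at this position moves the read-out beyond the scatter, towards higher toxicity in this test. For the compounds shown here, the 2,6-dimethylpyridin-4-yl group also separates from both other groups at this site and gives the lowest number in the set, with a 2.5-fold lower number from compound 1 to compound 4 (0.40 log units; beyond the scatter) and a 12-fold lower number from compound 2 to compound 4 (1.09 log units; beyond the scatter), the second being the only large step so far. No measurement at hand accounts for this shift.

The compounds shown leave open whether the shift is specific to methyl or would also follow from another group on the same carbon, such as ethyl, methoxy, chlorine or an amine. With only this one read-out, they also leave open whether the added methyl changes anything other than cytotoxicity in these cells, and whether the same exchange would act alike on a ring other than the 2-methylpyridin-4-yl.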